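From acetyl to 1-hydroxyethyl on compound 2

The compounds below may be only part of what the source reports. "The series", "measured", "known", "first", "only" and "open" are said of these compounds alone.

Of the compounds shown here, three with a shared core have been measured: compound 1 `CC(=O)c1ccc2[nH]c(-c3ccccc3)nc2c1`, compound 2 `COc1ccc(-c2nc3cc(C(C)=O)ccc3[nH]2)c(OC)c1` and compound 3 `COc1ccc(-c2nc3cc(C(C)=O)ccc3[nH]2)c(OC)c1OC`. In an ADME assay on Vero cells (Chlorocebus sabaeus) for cytotoxicity, read by MTT assay, with a stated time of 96 h (a lower number here means that less compound is tolerated, a higher number that more compound is tolerated), compound 1 gives > 100000 nM, a limit and not a number. Compound 2 gives > 100000 nM, which is likewise a limit. Compound 3 gives > 100000 nM, again a limit. Within the data shown here, the series so far is summed up by the limit of > 100000 nM in this assay, at which 3 of the 3 values shown sit, so compound 2 stands with the other two and has no number of its own.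

The next compound is compound 4 `COc1ccc(-c2nc3cc(C(C)O)ccc3[nH]2)c(OC)c1`, with 1-hydroxyethyl in place of acetyl on an aromatic carbon. Among the measured compounds shown here, the one measured step, a step that the two limits leave unreadable from compound 2 to compound 3, is methoxy in place of hydrogen on an aromatic carbon, a different change, and its size cannot be read. For the measured compounds named here, no measured step covers the acetyl group itself, so the expectation rests on the limit alone. Compound 2 sits at the limit of > 100000 nM, and no step beyond the scatter, in either direction, is expected in this assay. The expected step is small, estimated as a number no higher from compound 2 to compound 4 (the limit leaves the size open). The estimate for compound 4 is 100000 nM, with an expected range from 40000 nM to 200000 nM.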

Compound 4, half-maximal cytotoxic concentration: > 100000 nM
Compound 4 gave a limit, no number (the forecaster's own chance of this, stated with the estimate: 80%); the middle value sits exactly at the limit.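

Among these compounds, compound 2 and compound 4 both sit at a limit in this assay, so the change from acetyl to 1-hydroxyethyl gives no step that can be read. The compounds shown leave open the concentration at which any of them becomes cytotoxic, and whether acetyl and 1-hydroxyethyl differ at all in this respect: the limit of > 100000 nM in this assay, at which 4 of the 4 values shown sit.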